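A few compounds are considered here, and "the series" means these few. Any claim that something is new, unique, unknown or untested is made for them only; others in the source may bear on it.

Compound 1 `CCc1cn([C@H]2C[C@@H]3OP(=O)(O)OC[C@H]3O2)c(=O)[nH]c1=O` and compound 2 `CCCc1cn([C@H]2C[C@@H]3OP(=O)(O)OC[C@H]3O2)c(=O)[nH]c1=O` share one core and differ only in the chain on the ring. In a functional assay on L1210 cells (Mus musculus) (on this read-out lower numbers stand for stronger inhibition and higher numbers for weaker inhibition), compound 1 gives > 500 ug/mL, which is a limit of the assay and not a number. In this assay compound 2 gives > 500 ug/mL, again only a limit. The step that the two limits leave unreadable from compound 1 to compound 2 is therefore not readable. Compound 2 thus stands at the ceiling of the read-out, where every value shown sits (the limit of > 500 ug/mL in this assay, at which 2 of the 2 values shown sit). Compound 3 `CC(C)c1cn([C@H]2C[C@@H]3OP(=O)(O)OC[C@H]3O2)c(=O)[nH]c1=O` differs from compound 2 by isopropyl in place of propyl on an aromatic carbon. Within the data shown here, the only measured step, from compound 1 to compound 2, bears on this change, yet its size is hidden by the two limits, so no size can be drawn from it for this assay. The expectation for this assay is that the step that the limit leaves unreadable from compound 2 to compound 3 stays within the scatter. Compound 3 is estimated at 700 ug/mL (300 ug/mL to 2000 ug/mL), most probably reported once more only as a limit.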

Compound 3, concentration for 50% inhibition: > 500 ug/mL
Compound 3 ended at the assay's limit; the forecaster's own chance of this, stated with the estimate: 85%; the middle value lies beyond the limit too.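

In this assay no step among compound 1, compound 2 and compound 3 can be read, since all three stand only at a limit: the limit of > 500 ug/mL in this assay, at which 3 of the 3 values shown sit.

The compounds shown leave open whether any of these chains on the shared core gives a measurable value in this assay, and how the three compare.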